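Methoxy in Place of Chloro on a Hydroxy-Bearing Ring

This account rests on a few compounds, and the source may have more. Where it says the series, first, only, none or still open, it means among the compounds named here.

In a functional assay on MCF7 cells (Homo sapiens) for cytotoxicity, read by MTT assay, with a stated time of 72 h (on this read-out higher numbers stand for weaker inhibition and lower numbers for stronger inhibition), compound 2 `COc1cccc(/C=C2\CCC/C(=C\c3ccc(O)c(Cl)c3)C2=O)c1OC` gives 16400 nM and compound 1 `COc1cccc(/C=C2\CCC/C(=C\c3ccc(Cl)c(Cl)c3)C2=O)c1OC` gives 9000 nM, two numbers within the usual scatter of each other. Compound 3 `COc1cc(/C=C2\CCC/C(=C\c3cccc(OC)c3OC)C2=O)ccc1O` carries methoxy in place of chloro on an aromatic carbon, ortho to a hydroxy group: methoxy in place of chloro on an aromatic carbon. For the measured compounds named here, the one measured step on this ring is a 1.8-fold higher number from compound 1 to compound 2 (0.26 log units; within the scatter), which put hydroxy in place of a different chloro. It is only a loose guide, and no change beyond the scatter is expected in this assay. The expected step is a 1.1-fold lower number from compound 2 to compound 3 (0.04 log units; within the scatter). Compound 3 is estimated at 15000 nM, with a range of 6000 nM to 38000 nM.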

Compound 3, half-maximal inhibitory concentration: 11600 nM
Beside the measured number, compound 3's estimate is 1.3-fold (0.11 log units) above it, within the range that was stated.
By their numbers in this assay, from the lowest: compounds 1, 3 and 2 (each within the scatter of the next).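

In this assay, methoxy in place of chloro, ortho to a hydroxy group, gives a 1.4-fold lower number from compound 2 to compound 3 (0.15 log units; within the scatter), so this read-out does not separate the two groups at this position. Replacing the whole ring, with 4-hydroxy-3-methoxyphenyl in place of 3,4-dichlorophenyl, gives a 1.3-fold higher number from compound 1 to compound 3 (0.11 log units; within the scatter), so the two ring patterns are not separated either. Nothing available explains these results. On these data alone, whether an amine or a carboxylic acid on this aromatic carbon would give a step beyond the scatter remains open.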